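From 2,4-difluorobenzyl to 4-fluorobenzyl on the sulfonyl sulfur

The compounds below may be only part of what the source reports. "The series", "measured", "known", "first", "only" and "open" are said of these compounds alone.

In a functional assay on DU-145 cells (Homo sapiens) for inhibition, read by trypan blue exclusion, with a stated time of 72 h (on this read-out lower numbers stand for stronger inhibition and higher numbers for weaker inhibition), compound 1 `Cn1c(=O)c(S(=O)(=O)c2ccc(Cl)cc2Cl)cc2cnc(Nc3ccc4[nH]ccc4c3)nc21` gives 1000 nM and compound 2 `Cn1c(=O)c(C(=O)Nc2ccc(F)cc2F)cc2cnc(Nc3ccc4[nH]ccc4c3)nc21` gives 5000 nM while compound 3 `Cn1c(=O)c(S(=O)(=O)Cc2ccc(F)cc2F)cc2cnc(Nc3ccc4[nH]ccc4c3)nc21` gives 1000 nM as its reading. Compound 3 thus stands level with compound 1, the two sharing the lowest of the three numbers.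

Compound 4 `Cn1c(=O)c(S(=O)(=O)Cc2ccc(F)cc2)cc2cnc(Nc3ccc4[nH]ccc4c3)nc21` departs from compound 3 in one place, with hydrogen in place of fluoro on an aromatic carbon as the counted difference: hydrogen in place of fluoro on an aromatic carbon, ortho to a large group and meta to a fluoro group, turning 2,4-difluorobenzyl into 4-fluorobenzyl.

Within the data shown here, no measured step removes a single fluoro, so the evidence is indirect. The closest is no change at the digits printed from compound 1 to compound 3 (within the scatter) on placing 2,4-difluorobenzyl where 2,4-dichlorophenyl stood on the sulfonyl sulfur. The only larger move is a 5.0-fold higher number from compound 1 to compound 2 (0.70 log units; beyond the scatter) on placing (2,4-difluorophenyl)carbamoyl where (2,4-dichlorophenyl)sulfonyl stood, a swap that gives up the sulfonyl. Compound 4 keeps the sulfonyl, so the expected outcome is a 1.2-fold higher number from compound 3 to compound 4 (0.08 log units; within the scatter) and no shift beyond the scatter is anticipated. In this assay compound 4 is estimated at 1200 nM with an expected range of 500 nM to 3000 nM.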

Compound 4, half-maximal inhibitory concentration: 30000 nM
Compound 4: the middle estimate sits 25-fold (1.40 log units) below what was measured, and the stated range ends below it.
By their numbers in this assay, from the lowest: compounds 1 and 3 (each within the scatter of the next); then compound 2; then compound 4.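

In this assay, the place on the aromatic ring ortho to a large group and meta to a fluoro group proves far from indifferent: with hydrogen in place of fluoro, a change of one heavy atom, the reading moves by a 30-fold higher number from compound 3 to compound 4 (1.48 log units; beyond the scatter), whereas the earlier change on the sulfonyl sulfur had left the number unmoved, at no change at the digits printed from compound 1 to compound 3 (within the scatter). Keeping the sulfonyl therefore does not by itself hold the reading, since the step to the compound without it is a 6.0-fold higher number from compound 2 to compound 4 (0.78 log units; beyond the scatter), and the step from the 2,4-dichlorophenyl sulfone is a 30-fold higher number from compound 1 to compound 4 (1.48 log units; beyond the scatter). Nothing shown here gives a measured reason for this sensitivity to a single fluoro.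

Going by these compounds, what remains open is whether fluoro itself is required at this place or whether another group, such as chloro, methyl or methoxy, would serve as well. The compounds shown also leave open whether the same loss would follow on removing one chloro from the 2,4-dichlorophenyl group of compound 1, as this one pair is the only direct test of such a change.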